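Chloro for ethyl on the distal phenyl of compound 2

The source may hold more compounds than are shown below. What is called first, only, known or untested is meant among the compounds shown, and "the series" means these compounds.

Two members of the series have numbers in a functional assay on CHO cells for agonist activity at Free fatty acid receptor 1 (Homo sapiens), read by FLIPR and calcium flux, in the presence of a further agent that is not named here (a lower number here means that less compound is needed, a higher number that more compound is needed for the effect), so far. Compound 1 `O=C(O)CCc1ccc(OCc2coc(-c3ccccc3)n2)cc1` gives 700 nM in this assay. Compound 2 `CCc1ccc(-c2noc(COc3ccc(CCC(=O)O)cc3)n2)cc1` gives 210 nM in this assay, the lower of the two numbers; compound 1 sits at a higher number, and that gap lies beyond the usual scatter. Compound 2 is therefore the stronger of the two measured compounds.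

Compound 3 `O=C(O)CCc1ccc(OCc2nc(-c3ccc(Cl)cc3)no2)cc1` is not yet measured. The change from compound 2 to compound 3 is chloro in place of ethyl on an aromatic carbon. For the measured compounds named here, no measured pair shows this exchange, so nothing in the numbers points in either direction. The expected step in this assay is small, with a 1.2-fold higher number from compound 2 to compound 3 (0.08 log units; within the scatter) taken as none beyond the scatter. Compound 3 is estimated at 250 nM in this assay, within a range from 100 nM to 600 nM.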

Compound 3, half-maximal effective concentration: 540 nM
For compound 3 the middle estimate is 2.2-fold (0.33 log units) below the measured one, and the stated range covers the measured number.
By their numbers in this assay, from the lowest: compound 2; then compounds 3 and 1 (each within the scatter of the next).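

In this assay, for the compounds shown here, the change from 4-ethylphenyl to 4-chlorophenyl gives a 2.6-fold higher number from compound 2 to compound 3 (0.41 log units; beyond the scatter), the only step so far between compounds that differ in one place. This aromatic carbon, para to a large group, therefore does not tolerate every substituent equally: with chloro in place of ethyl, one heavy atom replaces two and the number moves modestly but beyond the scatter. Nothing available explains the step.

The compounds shown leave open whether a methyl group or a longer chain such as propyl at this carbon would follow ethyl or chloro. They also leave open how fluoro, methoxy or plain hydrogen at the same place would compare with compound 2 and compound 3.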